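Defining the ring stereocentre of compound 1: expectation for compound 4

A few compounds are considered here, and "the series" means these few. Any claim that something is new, unique, unknown or untested is made for them only; others in the source may bear on it.

Measured so far:
- compound 1 `Fc1ccc(-c2cn(C3CN4CCC3CC4)nn2)cc1`: 449 nM
- compound 2 `Oc1ccc(-c2cn(C3CN4CCC3CC4)nn2)cc1`: 627 nM
- compound 3 `FCCOc1cccc(-c2cn(C3CN4CCC3CC4)nn2)c1`: 1960 nM

In an assay on HEK293 cells for displacement of a labelled ligand from Neuronal acetylcholine receptor; alpha4/beta2 (Homo sapiens), read by scintillation counting, with a stated time of 120 min (a higher number here means a weaker inhibitor, a lower number a stronger inhibitor), compound 1 gives 449 nM; compound 2 stays with it, a 1.4-fold higher number from compound 1 to compound 2 (0.15 log units; within the scatter), and compound 3 at 1960 nM lies beyond the scatter of compound 1.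

Compound 4 `Fc1ccc(-c2cn([C@H]3CN4CCC3CC4)nn2)cc1` differs from compound 1 only in how the saturated ring carbon is drawn: the two compounds have the same atoms and bonds; at least one stereo element is drawn with a configuration in one of them and without one in the other: 1 of 3 stereo elements differ; a stereocentre at a saturated ring carbon is drawn without a configuration in compound 1 and R in compound 4. Among the measured compounds shown here, none of the measured steps changes a stereo element, so no step bears on this one; the substituent changes seen here say nothing about it. Either a smaller or a larger number than for compound 1 is possible, with no measured basis for a direction.

For compound 4 the expected value in this assay is therefore 320 nM (range 90 nM to 1800 nM), that is an expected step of a 1.4-fold lower number from compound 1 to compound 4 (0.15 log units; within the scatter), centred near compound 1 with a wide range.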

Compound 4, inhibition constant: 10400 nM
Beside the measured number, compound 4's estimate is 33-fold (1.51 log units) below it; the whole stated range lies below it.
By their numbers in this assay, from the lowest: compounds 1 and 2 (each within the scatter of the next); then compound 3; then compound 4.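

In this assay the stereocentre at the saturated ring carbon proves to be a strong determinant of the number, something the substituent changes could not show: defining it as R gives a 23-fold higher number from compound 1 to compound 4 (1.36 log units; beyond the scatter). Nothing else separates the two structures, so the step can be attributed only to this difference: the fact that one of compounds 1 and 4 is drawn with a defined configuration and the other without, at the place where they differ

The S configuration at this carbon remains open, so the configuration that accounts for the number of compound 1 is not settled. Also open, as far as these compounds go, is whether R has the same effect with hydroxy, an amine or a nitrile in place of fluoro.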